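A few compounds are considered here, and "the series" means these few. Any claim that something is new, unique, unknown or untested is made for them only; others in the source may bear on it.

In a functional assay on MGC-803 cells (Homo sapiens) for cytotoxicity, read by MTT assay, with a stated time of 48 h (a higher number here means a weaker inhibitor, a lower number a stronger inhibitor), compound 1 `O=C(CSc1ccc(Br)cc1)N1N=C(c2cc3ccccc3oc2=O)C[C@@H]1c1ccc(C(F)(F)F)cc1` gives 10800 nM and compound 2 `O=C(CSCc1ccco1)N1N=C(c2cc3ccccc3oc2=O)C[C@@H]1c1ccc(C(F)(F)F)cc1` gives 15200 nM as values within the scatter of each other. Compound 3 `O=C(CSc1ccc([N+](=O)[O-])cc1)N1N=C(c2cc3ccccc3oc2=O)C[C@@H]1c1ccc(C(F)(F)F)cc1` carries 4-nitrophenyl in place of (furan-2-yl)methyl on a sulfur. Going by the values given here, the only measured step bearing on this change is a 1.4-fold higher number from compound 1 to compound 2 (0.15 log units; within the scatter) and it stays within the scatter, with 4-bromophenyl as the leaving group on that sulfur. The expected step is a 1.3-fold lower number from compound 2 to compound 3 (0.10 log units; within the scatter) and nothing beyond the scatter is expected in this assay here. For compound 3 the estimated value is 12000 nM with an expected range of 5000 nM to 28000 nM in this series.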

Compound 3, half-maximal inhibitory concentration: 10200 nM
Compound 3: the middle estimate sits 1.2-fold (0.07 log units) above what was measured; low and high end bracket the measured number.
By their numbers in this assay, from the lowest: compounds 3, 1 and 2 (each within the scatter of the next).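

In this assay, 4-nitrophenyl in place of (furan-2-yl)methyl on the sulfur gives a 1.5-fold lower number from compound 2 to compound 3 (0.17 log units; within the scatter), and nitro in place of bromo on an aromatic carbon gives a 1.1-fold lower number from compound 1 to compound 3 (0.02 log units; within the scatter). The sulfur position has now carried three different groups with no step beyond the scatter, and this includes a change on the aromatic ring alone, which the earlier pair did not test. No available evidence accounts for these small steps. Still open, going by these compounds, is whether an amine or a carboxylic acid in place of the nitro, or a longer chain on the sulfur, would produce a step beyond the scatter.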